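Replacing the imidazole with a basic alkoxy chain

A few compounds are considered here, and "the series" means these few. Any claim that something is new, unique, unknown or untested is made for them only; others in the source may bear on it.

Compound 3 `Cc1cn(-c2ccc(Nc3nccc(-c4ccncc4)n3)cc2)cn1` stands at the weak end of the three: in a functional assay for inhibition, with Homo sapiens as the target (a higher number here means a weaker inhibitor, a lower number a stronger inhibitor), it reaches only the limit > 3000 nM, which is a limit and not a number (the limit of > 3000 nM in this assay, at which 1 of the 3 values shown sits). Going by the values given here, compound 1 `Fc1ccc(Nc2nccc(-c3ccncc3)n2)cc1` gives 1900 nM in this assay, and the one measured step at this carbon, an at least 1.5-fold higher number from compound 1 to compound 3 (0.19 log units; that floor lies within the scatter), is bounded only from below. Among the compounds with values here, compound 2 `CC1CCN(C(=O)COc2ccc(Nc3nccc(-c4ccncc4)n3)cc2)CC1` gives 300 nM in this assay; no step links it to compound 3, and their two values simply show compound 2 as the far stronger inhibitor. Compound 4 `CCN(CC)CCCOc1ccc(Nc2nccc(-c3ccncc3)n2)cc1` carries 3-(diethylamino)propoxy in place of 4-methyl-1H-imidazol-1-yl on an aromatic carbon. Within the data shown here, no measured step covers this change, so the expectation rests on compound 2. Compound 4 is expected to give 400 nM, in a range from 120 nM to 1500 nM, an expected step of an at least 7.5-fold lower number from compound 3 to compound 4 (0.87 log units; beyond the scatter).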

Compound 4, half-maximal inhibitory concentration: 1300 nM
The estimate for compound 4 lay 3.3-fold (0.51 log units) below the measured number; the measured number falls inside the stated range.
By their numbers in this assay, from the lowest: compound 2; then compounds 4 and 1 (each within the scatter of the next). At a limit, above all of these: compound 3.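

In this assay, 3-(diethylamino)propoxy on this aromatic carbon gives a real number where 4-methyl-1H-imidazol-1-yl gave none, with an at least 2.3-fold lower number from compound 3 to compound 4 (0.36 log units; beyond the scatter). That chain cannot be told apart from fluoro here, with a 1.5-fold lower number from compound 1 to compound 4 (0.16 log units; within the scatter), while 2-(diethylamino)ethyl is the weaker of the two groups on the saturated chain carbon bound to the oxygen, with a 4.3-fold higher number from compound 2 to compound 4 (0.64 log units; beyond the scatter). The first of these steps is only a floor, as compound 3 stands at a limit: the limit of > 3000 nM in this assay, at which 1 of the 4 values shown sits.

The compounds shown leave open how a shorter chain would read at this carbon. They also leave open whether a pyrrolidine or a morpholine at the chain end would differ from diethylamino.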